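The compounds below may be only part of what the source reports. "The series", "measured", "known", "first", "only" and "open" are said of these compounds alone.

Measured in a functional assay on SK-BR-3 cells (Homo sapiens) for antiproliferative activity; on this read-out higher numbers stand for weaker inhibition and lower numbers for stronger inhibition:
compound 1, `CC(C)=CCc1cc(C(=O)Nc2cc3ccc(OCCCN4CCCC4)c(C)c3oc2=O)ccc1O`, gives 720 nM.
compound 2, `CC(C)=CCc1cc(C(=O)Nc2cc3ccc(OCCCNCC(C)C)c(C)c3oc2=O)ccc1O`, gives 1030 nM.
compound 3, `CC(C)=CCc1cc(C(=O)Nc2cc3ccc(OCCCN(C(C)C)C(C)C)c(C)c3oc2=O)ccc1O`, gives 1600 nM.

Compound 1 holds the lowest of the three numbers in this assay; its gap to compound 2 is within the scatter, its gap to compound 3 modest but beyond it. Compound 4, `CC(C)=CCc1cc(C(=O)Nc2cc3ccc(OCCCN(C)C(C)(C)C)c(C)c3oc2=O)ccc1O`, differs from compound 1 as follows: methyl(tert-butyl)amino in place of pyrrolidin-1-yl on a saturated chain carbon, three bonds along the chain from an oxygen on an aromatic ring. The comparisons that bear on this are the two other amine replacements at the same place, a 1.4-fold higher number from compound 1 to compound 2 (0.16 log units; within the scatter) and a 2.2-fold higher number from compound 1 to compound 3 (0.35 log units; beyond the scatter); between those two, a 1.6-fold higher number from compound 2 to compound 3 (0.19 log units; within the scatter). Both replacements gave higher numbers, one within and one beyond the scatter, so for compound 4 in this assay a small rise is expected, a 1.5-fold higher number from compound 1 to compound 4 (0.18 log units; within the scatter), possibly still within the scatter. Compound 4 is therefore estimated at 1100 nM, range 600 nM to 2200 nM.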

Compound 4, half-maximal inhibitory concentration: 880 nM
Beside the measured number, compound 4's estimate is 1.3-fold (0.10 log units) above it; the measured number falls inside the stated range.
By their numbers in this assay, from the lowest: compounds 1, 4, 2 and 3 (each within the scatter of the next, the first and the last beyond it).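

In this assay, methyl(tert-butyl)amino, with no ring, stands level with pyrrolidin-1-yl at this place, a 1.2-fold higher number from compound 1 to compound 4 (0.09 log units; within the scatter) and so within the scatter, whereas the open-chain diisopropylamino of compound 3 lay beyond it. Compound 4 also cannot be separated from the other two amines, with a 1.2-fold lower number from compound 2 to compound 4 (0.07 log units; within the scatter) and a 1.8-fold lower number from compound 3 to compound 4 (0.26 log units; within the scatter), so it does not divide the series. Nothing at hand accounts for these numbers.

Open: whether a six-membered ring amine such as piperidine or morpholine keeps this level, and whether a shorter or longer chain to the amine changes it.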